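The compounds below may be only part of what the source reports. "The series", "measured", "known", "first", "only" and "open" are said of these compounds alone.

In a functional assay on SEM cells (Homo sapiens) for inhibition, read by MTT assay, with a stated time of 72 h (on this read-out lower numbers stand for stronger inhibition and higher numbers for weaker inhibition), compound 1 (`COc1cccc(/C=C/C(=O)Nc2cc(OC)c(OC)c(OC)c2)c1`) gives 18200 nM and compound 2 (`C=C(Br)C(=O)Nc1cccc(/C=C/C(=O)Nc2ccccc2)c1`) gives 1100 nM as the lower of the two numbers, a gap beyond the scatter. Compound 3 (`C=C(Br)C(=O)Nc1cccc(/C=C/C(=O)Nc2ccc(SC(F)(F)F)cc2)c1`) is still unmeasured and carries (trifluoromethyl)sulfanyl in place of hydrogen on an aromatic carbon, para to a large group ((trifluoromethyl)sulfanyl in place of hydrogen on an aromatic carbon). Within the data shown here, no measured pair shows such a change, so starting from compound 2 at 1100 nM only a modest move toward lower numbers is expected in this assay and possibly none beyond the scatter. The expected change is a 2.2-fold lower number from compound 2 to compound 3 (0.34 log units; beyond the scatter) by this estimate. Compound 3 is estimated at 500 nM within a range of 150 nM to 1600 nM for now.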

Compound 3, half-maximal inhibitory concentration: 12700 nM
Estimate against measurement, compound 3: 25-fold (1.40 log units) below; measured number outside the range, above it.
By their numbers in this assay, from the lowest: compound 2; then compounds 3 and 1 (each within the scatter of the next).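

In this assay, (trifluoromethyl)sulfanyl in place of hydrogen on an aromatic carbon, para to a large group, gives a 12-fold higher number from compound 2 to compound 3 (1.06 log units; beyond the scatter). This first measured change at this position shows that inhibition here responds strongly to the substituent, and that this group weakens it. Nothing available explains the loss. As far as these compounds go, it remains open whether a fluorine atom, an amine or a carboxylic acid at the same position would keep the number near that of compound 2. From the compounds shown here alone, it is equally open whether the loss belongs to the position or to (trifluoromethyl)sulfanyl itself.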